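The source may hold more compounds than are shown below. What is called first, only, known or untested is meant among the compounds shown, and "the series" means these compounds.

Measured so far:
compound 1, `CS(=O)(=O)c1ccc(-c2cnc3ccc(-c4cccc(S(=O)(=O)CCO)c4)nn23)cc1` — in a physicochemical assay for solubility, at pH 2 (a lower number here means a less soluble compound, a higher number a more soluble compound), compound 1 gives 190000 nM
compound 2, `CS(=O)(=O)c1ccc(-c2cnc3ccc(-c4cccc(C(=O)NCCO)c4)nn23)cc1` — in this assay compound 2 gives > 200000 nM

The value for compound 2 is a limit of the assay and not a number (the limit of > 200000 nM in this assay, at which 1 of the 2 values shown sits). Among the compounds with values here, the single measured step, an at least 1.0-fold higher number from compound 1 to compound 2 (0.02 log units; that floor lies within the scatter), therefore sets only a floor, and that floor lies within the scatter. Compound 3, `CS(=O)(=O)c1ccc(-c2cnc3ccc(-c4cccc(C(=O)N5CCC(O)CC5)c4)nn23)cc1`, differs from compound 2 by 4-hydroxypiperidin-1-yl in place of (2-hydroxyethyl)amino on a carbonyl carbon. Within the data shown here, no measured step covers a change on the carbonyl carbon; the one step at hand concerned the substituent on an aromatic carbon, and compound 2 already sits at the limit of this assay. The expectation for compound 3 is accordingly no step beyond the scatter, a number no higher from compound 2 to compound 3 (the limit leaves the size open), with a fair chance that this assay again reports only a limit. Compound 3 is estimated at 200000 nM, within 70000 nM to 200000 nM.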

Compound 3, solubility: > 200000 nM
Compound 3: a limit, no number; the forecaster's own chance of this, stated with the estimate: 60%; the middle value lies on the limit itself.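

On the carbonyl carbon, 4-hydroxypiperidin-1-yl in place of (2-hydroxyethyl)amino leaves the compound at the top of the range of this assay, so a six-membered ring at this position still gives only a limit and not a number. With (4-hydroxypiperidin-1-yl)carbonyl in place of (2-hydroxyethyl)sulfonyl on an aromatic carbon, the result is an at least 1.0-fold higher number from compound 1 to compound 3 (0.02 log units; that floor lies within the scatter), which again sets only a floor. The step between the two amides cannot be read, because both values are limits: the limit of > 200000 nM in this assay, at which 2 of the 3 values shown sit.

Going by these compounds, it remains open whether an unsubstituted piperidine on the carbonyl carbon, or a carboxylic acid on the same aromatic carbon, would give a readable number in this assay. Any difference among these amides would show only in such a number.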